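Trading a Sulfonyl Linker for a Plain Chain

A few compounds are considered here, and "the series" means these few. Any claim that something is new, unique, unknown or untested is made for them only; others in the source may bear on it.

Compound 1, `CC(=O)Oc1ccccc1C(=O)OCOC(=O)c1ccc(S(=O)(=O)CCCO[N+](=O)[O-])cc1`, is measured in an ADME assay on a cell-free system (serum, Homo sapiens) for metabolic stability, read by HPLC, tested at 250 uM; on this read-out lower numbers stand for a shorter-lived compound and higher numbers for a longer-lived compound. In this assay compound 1 reaches only a limit, < 0.0167 h, which is the limit of < 0.0167 h in this assay, at which 1 of the 2 values shown sits. Compound 2, `CC(=O)Oc1ccccc1C(=O)OC(C)OC(=O)c1ccc(SCCCO[N+](=O)[O-])cc1`, gives 0.0733 h in this assay. Compound 3, `CC(=O)Oc1ccccc1C(=O)OCOC(=O)c1ccc(CCCO[N+](=O)[O-])cc1`, differs from compound 1 by 3-(nitrooxy)propyl in place of (3-(nitrooxy)propyl)sulfonyl on an aromatic carbon. Among the measured compounds shown here, no measured pair shows this change, so only a cautious expectation can be formed. The step of an at least 2.3-fold higher number from compound 1 to compound 3 (0.37 log units; beyond the scatter) is expected to lengthen the half-life modestly, beyond the usual scatter. Compound 3 is therefore estimated at 0.04 h, within 0.0167 h to 0.1 h.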

Compound 3, half-life in the serum assay: 0.0317 h
For compound 3 the middle estimate is 1.3-fold (0.10 log units) above the measured one, within the range that was stated.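

In the serum assay compound 1 gives only a limit. In the serum assay the plain 3-(nitrooxy)propyl chain in place of the sulfonyl-linked one can therefore be read only as a floor, an at least 1.8-fold higher number from compound 1 to compound 3 (0.27 log units; that floor lies within the scatter) and no more than that. The clearer difference lies elsewhere: in a physicochemical assay for metabolic stability, read by HPLC, in phosphate buffer, with a stated time of 3 h, at pH 7.4, tested at 0.5 mM (a higher number here means that more of the compound is left, a lower number that less of the compound is left), compound 1 keeps 70% while compound 3 keeps 100% of the compound, a gap beyond the usual scatter. On these data alone, what remains open is how a longer chain carrying the nitrooxy end would behave on these read-outs. The same holds for an amide linker at this place on the ring.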